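Compound 3 to compound 4: one phenyl group exchanged

A few compounds are considered here, and "the series" means these few. Any claim that something is new, unique, unknown or untested is made for them only; others in the source may bear on it.

Measured in a functional assay on Caco-2 cells (Homo sapiens) for inhibition, read by MTT assay, with a stated time of 48 h, tested at 10 uM (on this read-out lower numbers stand for less inhibition of growth and higher numbers for more inhibition of growth at the one concentration tested), so far:
compound 1 `CCN(CC)Cc1c(O)c([C@H]2CCN(C)C[C@H]2O)c2oc(C)cc(=O)c2c1O` gives 17%
compound 2 `Cc1cc(=O)c2c(O)c(CN3CCC(c4ccccc4)CC3)c(O)c([C@H]3CCN(C)C[C@H]3O)c2o1` gives 21%
compound 3 `Cc1oc2c([C@H]3CCN(C)C[C@H]3O)c(O)cc(O)c2c(=O)c1C(O)c1ccc(F)c(Br)c1` gives 6%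

Of these three, compound 3 stands lowest in this assay and lies beyond the usual scatter from both of the others. Compound 1 is the nearer of the two, and compound 2 is the further.

The next compound to be tested is compound 4 `Cc1oc2c([C@H]3CCN(C)C[C@H]3O)c(O)cc(O)c2c(=O)c1C(O)c1cccc(Cl)c1Cl`. It keeps the frame of compound 3 and changes one group: 2,3-dichlorophenyl in place of 3-bromo-4-fluorophenyl on a saturated chain carbon bound to an aromatic carbon and an oxygen on a saturated carbon describes 2,3-dichlorophenyl in place of 3-bromo-4-fluorophenyl on a saturated chain carbon bound to an aromatic carbon and an oxygen on a saturated carbon. The same difference can be read as (2,3-dichlorophenyl)(hydroxy)methyl replacing (3-bromo-4-fluorophenyl)(hydroxy)methyl.

Among the compounds with values here, no two measured compounds differ in only one place, so the data give no direct measure of a change of this kind. The expectation therefore rests on compound 3 (6%), the closest measured relative. The expected change, a number 3 percentage points higher from compound 3 to compound 4 (within the scatter) in this assay, is small, with no step beyond the scatter in either direction. Compound 4 is estimated at 9%, with an expected range from 0% to 22% in this read-out.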

Compound 4, percent growth inhibition at one concentration: 3%
Beside the measured number, compound 4's estimate is 6 percentage points above it; low and high end bracket the measured number.
By their numbers in this assay, from the lowest: compounds 4 and 3 (each within the scatter of the next); then compounds 1 and 2 (each within the scatter of the next).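

In this assay, within the data shown here, the exchange of 3-bromo-4-fluorophenyl for 2,3-dichlorophenyl on a saturated chain carbon bound to an aromatic carbon and an oxygen on a saturated carbon gives the first step between two measured compounds that differ in one place, a number 3 percentage points lower from compound 3 to compound 4 (within the scatter), and this step lies within the scatter. At this position, then, two phenyl groups of equal heavy-atom count but with different halogens are not told apart by this read-out at the one concentration tested, with compound 3 at 6% and compound 4 at 3% standing within the scatter of each other. Nothing measured here offers an explanation for this result.

From the compounds shown here alone, both compounds carry a halogen-bearing phenyl group at this position, so it remains open how a group of another kind, such as a pyridyl ring, an aminophenyl or a carboxyphenyl group, would read there. Also open, going by these compounds, is what the hydroxy group on the same chain carbon contributes, and how a carbonyl in its place would read.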